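Propyl to tert-Butyl on the Thiophene-Bearing Analogue

The source may hold more compounds than are shown below. What is called first, only, known or untested is meant among the compounds shown, and "the series" means these compounds.

Three measured compounds share one core and differ only in the group on an oxygen next to a carbonyl group and in the ring on a saturated ring carbon. Compound 1 `CCCOC(=O)C1=C(C)NC(=O)NC1c1ccoc1` is measured in an assay on membranes from CHO cells for displacement of a labelled ligand from adenosine receptor A1 (Homo sapiens), read by scintillation counting, with a stated time of 60 min, tested at 1 uM (a higher number here means more inhibition at the concentration tested (going by the name of the read-out), a lower number less inhibition), where it gives 50%. Compound 2 `CC1=C(C(=O)OC(C)(C)C)C(c2ccoc2)NC(=O)N1` gives 11% in this assay, and compound 3 `CCCOC(=O)C1=C(C)NC(=O)NC1c1cccs1` gives 43%. Among these three numbers compound 3 stands second highest: its nearest neighbour is compound 1, separated by a number 7 percentage points lower from compound 1 to compound 3 (within the scatter), while compound 2 lies well below it, beyond the scatter.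

Compound 4 `CC1=C(C(=O)OC(C)(C)C)C(c2cccs2)NC(=O)N1` has not yet been measured. It differs from compound 3 in one place: tert-butyl in place of propyl on an oxygen next to a carbonyl group. Exactly this change has been measured once, between compound 1 and compound 2, where it brought a number 39 percentage points lower from compound 1 to compound 2 (beyond the scatter). The other measured step, a number 7 percentage points lower from compound 1 to compound 3 (within the scatter), concerns the ring rather than this group, and it shows that compound 1 and compound 3 behave alike, so the change seen from compound 1 to compound 2 is expected to carry over to compound 3. A drop of similar size, beyond the scatter, is therefore expected in this assay. For compound 4 the expected value is 6%, within a range from 0% to 20%, an estimated step of a number 37 percentage points lower from compound 3 to compound 4 (beyond the scatter).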

Compound 4, a percentage reported as inhibition, at one concentration (the size of the read-out at that concentration, not a potency): 26%
Beside the measured number, compound 4's estimate is 20 percentage points below it, outside the stated range (above it).
By their numbers in this assay, from the lowest: compound 2; then compound 4; then compounds 3 and 1 (each within the scatter of the next).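

On the shared core carrying thiophen-2-yl, tert-butyl in place of propyl still lowers the number in this assay, a number 17 percentage points lower from compound 3 to compound 4 (beyond the scatter), so the direction of the change holds, but its size does not carry over from the furan-3-yl pair: the same change on two cores in this assay, a number 39 percentage points lower (beyond the scatter) from compound 1 to compound 2 and a number 17 percentage points lower (beyond the scatter) from compound 3 to compound 4, 22 percentage points apart, beyond the scatter of two such steps

The ring on the saturated ring carbon shows the same dependence from the other side: with propyl on the oxygen the swap from furan-3-yl to thiophen-2-yl stays within the scatter, whereas with tert-butyl it gives a number 15 percentage points higher from compound 2 to compound 4 (beyond the scatter): the same change on two cores in this assay, a number 7 percentage points lower (within the scatter) from compound 1 to compound 3 and a number 15 percentage points higher (beyond the scatter) from compound 2 to compound 4, 22 percentage points apart, beyond the scatter of two such steps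

Across these four compounds, then, the two changes do not act independently, so a step measured with one ring cannot simply be added to a compound with the other.

Four compounds cannot show whether this dependence extends beyond these two rings, for example to a phenyl ring on the saturated ring carbon. They also leave open how an isopropyl group or a longer chain such as butyl on the oxygen would read in this assay, with either ring in place.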